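The source may report more compounds than this note shows. Statements on the series, on what has been measured and on what is new or still open speak of the compounds shown alone.

Measured compounds in an assay on isolated protein for inhibition of thyroid hormone receptor alpha (Homo sapiens), read by fluorescence polarization; on this read-out higher numbers stand for weaker inhibition and lower numbers for stronger inhibition:

compound 1 `CC1CCN(C(=O)CN(C)C(=O)c2ccc(S(C)(=O)=O)c([N+](=O)[O-])c2)CC1`: > 60000 nM
compound 2 `CS(=O)(=O)c1ccc(C(=O)N2CCC(C(=O)N3CCN(c4ccc(F)cc4)CC3)CC2)cc1[N+](=O)[O-]`: > 60000 nM
compound 3 `CN1CCN(C(=O)CNC(=O)c2ccc(S(C)(=O)=O)c([N+](=O)[O-])c2)CC1`: > 60000 nM

Each of these three values is a limit of this assay rather than a number. Compound 1 therefore has no measured inhibitory concentration; its value marks only the limit. The same holds for compound 2 and for compound 3, so nothing orders the three against one another, and compound 1 stands at the same limit as the other two, which the limit of > 60000 nM in this assay, at which 3 of the 3 values shown sit, records.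

The step under consideration goes from compound 1 to compound 4 `CN(CC(=O)N1CCc2ccccc2C1)C(=O)c1ccc(S(C)(=O)=O)c([N+](=O)[O-])c1`. The structural change is 1,2,3,4-tetrahydroisoquinolin-2-yl in place of 4-methylpiperidin-1-yl on a carbonyl carbon. The shared core of compound 1, with the nitro-substituted methylsulfonyl-aryl amide and the saturated chain carbon between the two carbonyls, is untouched; only the amine at the second carbonyl carbon is exchanged.

Within the data shown here, no step between measured compounds is available, so the size of the expected change rests only on the fact that all three measured amide variants sit at the limit. Exchange of one amide amine for another within this set has not produced a measurable value, and no direction can be read from the data. The step from compound 1 to compound 4 is expected to be a number no higher from compound 1 to compound 4 (the limit leaves the size open), that is, none beyond the scatter, with the assay most likely again reporting a limit. Compound 4 is estimated at 60000 nM, within 20000 nM to 200000 nM.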

Compound 4, half-maximal inhibitory concentration: > 60000 nM
Compound 4: no number, only a limit (the forecaster's own chance of this, stated with the estimate: 85%); the middle value lies on the limit itself.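

Compound 1 and compound 4 both give only a limit in this assay, so the exchange of 4-methylpiperidin-1-yl for 1,2,3,4-tetrahydroisoquinolin-2-yl yields no readable step. The compounds shown leave open whether any amine on this carbonyl carbon gives a measurable inhibitory concentration, and how the four compounds rank: the limit of > 60000 nM in this assay, at which 4 of the 4 values shown sit.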